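A few compounds are considered here, and "the series" means these few. Any claim that something is new, unique, unknown or untested is made for them only; others in the source may bear on it.

Of the compounds shown here, two have so far been measured in a functional assay on RPMI 8402 cells (Homo sapiens) for cytotoxicity; a higher number here means a weaker inhibitor, a lower number a stronger inhibitor. Compound 1 `COc1ccc(-c2ccc3[nH]c(-c4ccc5[nH]c(-c6ccc7[nH]cnc7c6)nc5c4)nc3c2)cc1` gives 90 nM in this assay. Compound 2 `c1ccc(-c2ccc3[nH]c(-c4ccc5[nH]c(-c6ccc7[nH]cnc7c6)nc5c4)nc3c2)cc1` carries hydrogen in place of methoxy on an aromatic carbon, and in this assay compound 2 gives 90 nM; the step of no change at the digits printed from compound 1 to compound 2 (within the scatter) lies within the scatter, so compound 2 stands level with compound 1 at the digits shown, with no other measured neighbour to compare against. Compound 3 `Clc1ccc(-c2ccc3[nH]c(-c4ccc5[nH]c(-c6ccc7[nH]cnc7c6)nc5c4)nc3c2)cc1` is the next compound, and it differs from compound 2 by chloro in place of hydrogen on an aromatic carbon. For the measured compounds named here, only one measured step bears on this change, the exchange of methoxy for hydrogen on an aromatic carbon of the same outer ring, and that step no change at the digits printed from compound 1 to compound 2 (within the scatter) stayed within the scatter. The change to compound 3 is of the same kind, a small exchange at that position, so compound 3 is expected to show no change at the digits printed from compound 2 to compound 3 (within the scatter) in this assay. The estimate for compound 3 is therefore 90 nM, with a range from 40 nM to 200 nM, pending the measurement.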

Compound 3, half-maximal inhibitory concentration: 90 nM
Beside the measured number, compound 3's estimate shows no gap at the digits printed; measured number inside the range.
By their numbers in this assay, from the lowest: compounds 1, 2 and 3 (each within the scatter of the next).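

At this place, on an aromatic carbon of the outer ring and para to a large group, the exchange of hydrogen for chloro gives no change at the digits printed from compound 2 to compound 3 (within the scatter) in this assay and the direct exchange of methoxy for chloro gives no change at the digits printed from compound 1 to compound 3 (within the scatter) in the same test. For the compounds shown here, the earlier pair compared only one group with hydrogen, whereas three different occupants of this place can now be compared: a hydrogen atom, a methoxy group and a single chlorine atom. this assay does not separate these three, and no supporting measurement is available to explain this outcome.

The compounds shown leave open whether an amine, a carboxylic acid or a longer chain such as butoxy at this same place would also stay level with these three in this assay and thus show how widely the place accepts different groups. They also leave open whether chloro or methoxy would give the same result on another carbon of the outer ring, or whether a change elsewhere in the shared core would move the read-out.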